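The source may hold more compounds than are shown below. What is called first, only, known or untested is meant among the compounds shown, and "the series" means these compounds.

Measured so far:
- compound 1, `O=S(=O)(/C=C/c1ccc(O)c(O)c1)CC1CCC1`: 8800 nM
- compound 2, `O=S(=O)(/C=C/c1ccc(O)c(O)c1)CCC1CCCC1`: 6800 nM

Both compounds were tested in a functional assay, read by fluorescence and spectrophotometry, with a stated time of 1 h; on this read-out higher numbers stand for an effect only at larger amounts of compound and lower numbers for an effect already at smaller amounts. Compound 2 gives the lowest of the two numbers, but its nearest neighbour, compound 1, differs from it only within the usual scatter, so the two cannot be told apart on these data. Going by the values given here, the only measured step, a 1.3-fold lower number from compound 1 to compound 2 (0.11 log units; within the scatter), exchanges one small ring for a slightly larger one on the chain bound to the sulfonyl sulfur and produces no change beyond the scatter.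

Compound 3, `C=CCCCCCS(=O)(=O)/C=C/c1ccc(O)c(O)c1`, is not yet measured. It differs from compound 2 as follows: pent-4-en-1-yl in place of cyclopentyl on a saturated chain carbon, two bonds along the chain from a sulfonyl sulfur. This is again a change in the saturated chain on the sulfonyl side while the shared core stays the same. Among the compounds with values here, the one step in hand bears on it loosely, as it also varied that chain, and it was flat. There are no data on opening a ring into an open chain, so the expectation leans on that flat step alone.

Compound 3 is therefore expected to give about 7000 nM in this assay, within 3000 nM to 16000 nM, a step of a 1.0-fold higher number from compound 2 to compound 3 (0.01 log units; within the scatter) that is expected to stay within the scatter.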

Compound 3, half-maximal effective concentration: 7100 nM
For compound 3 the middle estimate is 1.0-fold (0.01 log units) below the measured one; the range from low to high includes it.
By their numbers in this assay, from the lowest: compounds 2, 3 and 1 (each within the scatter of the next).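

In this assay the exchange of a ring for an open chain, with the same atoms joined differently, gives a 1.0-fold higher number from compound 2 to compound 3 (0.02 log units; within the scatter) and thus extends what the earlier ring-for-ring step showed: at this position on the sulfonyl side, losing the cyclopentyl ring and gaining a double bond outside aromatic rings causes no change beyond the scatter. The comparison of the open chain with the smaller ring, hex-5-en-1-yl in place of cyclobutyl on a saturated chain carbon bound to a sulfonyl sulfur, gives a 1.2-fold lower number from compound 1 to compound 3 (0.09 log units; within the scatter) and is equally flat, so compounds 1, 2 and 3 cannot be told apart on this read-out, whether the group there is a ring or an open chain. No supporting information is available to explain why these changes leave the number where it stands.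

As far as these compounds go, it remains open whether an amine or a carboxylic acid at the end of this chain, or a much longer chain such as dodecyl, would move the number beyond the scatter. From the compounds shown here alone, it is also open whether a phenyl ring in this place would do so, and what a change to the shared core would bring.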